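Cytotoxicity outlook for a hydroxyethyl-bearing analogue of compound 3

This account rests on a few compounds, and the source may have more. Where it says the series, first, only, none or still open, it means among the compounds named here.

The series shares one core, seen in compound 1 `Cc1ccc2cc(CN(Cc3ccc(F)cc3)Cc3ccc(C(C)(C)C)cc3)c(=O)[nH]c2c1`, compound 2 `Cc1cccc2cc(CN(Cc3ccc(F)cc3)Cc3ccc(C(C)(C)C)cc3)c(=O)[nH]c12` and compound 3 `CCCOc1ccc(CN(Cc2ccc(C(C)(C)C)cc2)Cc2cc3cc(C)ccc3[nH]c2=O)cc1`. All three were considered in a toxicity assay on MDCK cells (Canis lupus familiaris) for cytotoxicity, read by crystal violet staining, with a stated time of 48 h; on this read-out higher numbers stand for lower toxicity in this test and lower numbers for higher toxicity in this test. Compound 1 gave only a limit in this assay, > 33000 nM, so no number is known for it. For compound 2 the entry in this assay reads "not determined" (no result reported), so no result was reported. Compound 3 also gave only a limit in this assay, > 5000 nM, and therefore stands without a single number among the values shown: one further value is a limit as well, and one entry carries no number at all.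

Compound 4 `Cc1ccc2[nH]c(=O)c(CN(Cc3ccc(C(C)(C)C)cc3)[C@H](CO)c3ccccc3)cc2c1` has not yet been measured in this assay. It differs from compound 3 in one place: 2-hydroxy-1-phenylethyl in place of 4-propoxybenzyl on an amine nitrogen. Within the data shown here, no step between two measured compounds exists here, so the size of the change cannot be read from a measured pair. Both values known in this assay are limits the limit of > 33000 nM in this assay, at which 1 of the 3 values shown sits (the limit of > 5000 nM in this assay, at which 1 of the 3 values shown sits), which gives no sign of a difference beyond the scatter within the series.

For compound 4 the expected outcome in this assay is again a limit rather than a number, with an estimated value of 20000 nM and a range from 5000 nM to 100000 nM. The expected step that the limit leaves unreadable from compound 3 to compound 4 is taken to lie within the scatter.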

Compound 4, half-maximal cytotoxic concentration: > 10000 nM
Compound 4: no number, only a limit; the forecaster's own chance of this, stated with the estimate: 70%; the middle value is on the limit's open side.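

In this assay compound 4 gives only a limit, > 10000 nM. Among these compounds, compound 3 also gives only a limit, > 5000 nM, and no step between compound 3 and compound 4 can be read. The compounds shown leave open where the half-maximal cytotoxic concentration of either compound lies, and whether 2-hydroxy-1-phenylethyl in place of 4-propoxybenzyl shifts it at all.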